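The compounds below may be only part of what the source reports. "The series", "measured", "known", "first", "only" and "open" are said of these compounds alone.

In a functional assay on AGS cells (Homo sapiens) for inhibition, read by MTT assay, with a stated time of 48 h; a lower number here means a stronger inhibitor of growth, a higher number a weaker inhibitor of growth:
- compound 1 `O=[N+]([O-])c1ccc(-c2cc(-c3ccc(Br)cc3)n[nH]2)cc1`: 14600 nM
- compound 2 `FC(F)(F)c1ccc(-c2cc(-c3ccccc3-c3ccccc3)n[nH]2)cc1`: 6900 nM

Of these two numbers, compound 2 holds the lower one, and compound 1 sits beyond the usual scatter above it. Compound 3 `Oc1ccc(-c2cc(-c3ccccc3-c3ccccc3)n[nH]2)cc1` has not been measured; it differs from compound 2 in one place: hydroxy in place of trifluoromethyl on an aromatic carbon. Going by the values given here, no measured pair shows what this change does, so the step from compound 2 to compound 3 is expected to stay within the scatter, with room for a shift either way. Compound 3 is estimated to give 8000 nM, between 2500 nM and 25000 nM, which means an expected step of a 1.2-fold higher number from compound 2 to compound 3 (0.06 log units; within the scatter).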

Compound 3, concentration for 50% growth inhibition: 9200 nM
Compound 3: the middle estimate sits 1.2-fold (0.06 log units) below what was measured; measured number inside the range.
By their numbers in this assay, from the lowest: compounds 2, 3 and 1 (each within the scatter of the next, the first and the last beyond it).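

In this assay, putting hydroxy in place of trifluoromethyl gives a 1.3-fold higher number from compound 2 to compound 3 (0.12 log units; within the scatter) and so no readable change. Going by these compounds alone, this gives the first direct comparison at this position, para to a large group: the smaller hydroxy brings a hydrogen-bond donor and acceptor that trifluoromethyl lacks, yet the two compounds read alike. Nothing available explains this likeness. Still open, going by these compounds, is whether an amine or a carboxylic acid at this position would also leave the number unchanged, and whether the same swap would read alike on another core.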